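A Second Aromatic Ring Added to Compound 1

The source may report more compounds than this note shows. Statements on the series, on what has been measured and on what is new or still open speak of the compounds shown alone.

For the measured compounds named here, compound 1 `O=[N+]([O-])c1cn2c(n1)OC[C@@H](OCC#Cc1ccc(OC(F)(F)F)cc1)C2` gives 0.77 ug/mL in a physicochemical assay for solubility, read by HPLC, at pH 7 (on this read-out higher numbers stand for higher solubility and lower numbers for lower solubility), the second highest of the three numbers known. Compound 2 `O=[N+]([O-])c1cn2c(n1)OC[C@@H](OC/C=C/c1ccc(OC(F)(F)F)cc1)C2` gives 1.5 ug/mL, which lies within the scatter of compound 1. Compound 3 `O=[N+]([O-])c1cn2c(n1)OC[C@@H](Oc1ccc(-c3ccc(OC(F)(F)F)cc3)nc1)C2` gives 0.27 ug/mL, beyond the scatter below compound 1. Compound 4 `O=[N+]([O-])c1cn2c(n1)OC[C@@H](OCC#Cc1ccc(-c3ccc(OC(F)(F)F)cc3)cc1)C2` has not yet been measured; it differs from compound 1 by 4-(trifluoromethoxy)phenyl in place of trifluoromethoxy on an aromatic carbon on an aromatic carbon. Going by the values given here, no measured pair shows this exact change, so the step can only be guessed. A downward step is expected, beyond the scatter, because compound 3 gives 0.27 ug/mL. Compound 4 is therefore estimated at 0.2 ug/mL, with a range from 0.05 ug/mL to 0.6 ug/mL, meaning a step of a 3.9-fold lower number from compound 1 to compound 4 (0.59 log units; beyond the scatter) is expected.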

Compound 4, solubility: 0.07 ug/mL
For compound 4 the middle estimate is 2.9-fold (0.46 log units) above the measured one, within the range that was stated.
By their numbers in this assay, from the lowest: compound 4; then compound 3; then compounds 1 and 2 (each within the scatter of the next).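

In this assay, for the compounds shown here, the place on the six-membered aromatic ring of carbon only, para to a large group, proves sensitive: 4-(trifluoromethoxy)phenyl in place of trifluoromethoxy gives an 11-fold lower number from compound 1 to compound 4 (1.04 log units; beyond the scatter) and is the first one-place step in this set. The step is large and lies beyond the scatter. Nothing at hand accounts for its size. Open, as far as these compounds go, is how an amine or a carboxylic acid on the added ring would read, and whether the same replacement on compound 2 would give a comparable step.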